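The source may hold more compounds than are shown below. What is called first, only, known or untested is meant among the compounds shown, and "the series" means these compounds.

Measured in a functional assay on HL-60 cells (Homo sapiens) for cytotoxicity, read by MTT assay, with a stated time of 48 h; on this read-out lower numbers stand for stronger inhibition and higher numbers for weaker inhibition:
- Compound 1 `COc1cc(NC(=O)n2cc(-c3ccc(O)cc3)n(-c3cc(OC)c(OC)c(OC)c3)c2=O)cc(OC)c1OC`: 6300 nM
- Compound 2 `COc1cc(-n2c(-c3ccccc3)cn(C(C)=O)c2=O)cc(OC)c1OC`: 5600 nM

Compound 2, at 5600 nM, stands level with compound 1 within the scatter, so these two numbers do not separate the compounds. Compound 3 `COc1ccc(-c2cn(C(C)=O)c(=O)n2-c2cc(OC)c(OC)c(OC)c2)cc1N`, not yet measured, has 3-amino-4-methoxyphenyl in place of phenyl on an aromatic carbon. All else in compound 2 stays the same. Neither measured compound shows a step for this change, so the expectation rests on the structural change alone and is uncertain. In this assay, a large move toward stronger inhibition, well beyond the scatter, is expected. The estimated change is a 70-fold lower number from compound 2 to compound 3 (1.85 log units; beyond the scatter). Compound 3 is expected at 80 nM, with an estimated range of 8 nM to 1500 nM.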

Compound 3, half-maximal inhibitory concentration: 400 nM
The estimate for compound 3 lay 5.0-fold (0.70 log units) below the measured number, within the range that was stated.
By their numbers in this assay, from the lowest: compound 3; then compounds 2 and 1 (each within the scatter of the next).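

In this assay, putting 3-amino-4-methoxyphenyl in place of phenyl on an aromatic carbon of the five-membered ring gives a 14-fold lower number from compound 2 to compound 3 (1.15 log units; beyond the scatter), the only step among these compounds and one that lies beyond the scatter. This shows that the number responds strongly to what is carried on the aromatic ring at this position, which the two earlier compounds, differing in more than one place, could not show. No measurement at hand accounts for the size of this step.

The amino and methoxy groups enter together, so the compounds shown do not divide the step between them, and a ring carrying only one of the two would be needed to do so. Also open, on these data alone, is how a hydroxyl or a dimethylamino group in place of the amino group would read here.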